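This account rests on a few compounds, and the source may have more. Where it says the series, first, only, none or still open, it means among the compounds named here.

All the compounds here share one core and are compared in a physicochemical assay for solubility; on this read-out higher numbers stand for higher solubility and lower numbers for lower solubility. Compound 1 `CNC(=O)c1cc(C(=O)NC2CC2)cn(Cc2cccc(F)c2)c1=O` is reported only as a limit, >= 133 ug/mL. Compound 2 `CNC(=O)c1cc(C(=O)NC2CC2)cn(Cc2cccc([C@@H](C)O)c2)c1=O` is also reported only as a limit, >= 131 ug/mL. Compound 3 `CNC(=O)c1cc(C(=O)NC2CC2)cn(CC2CCCOC2)c1=O`, the starting point of this step, likewise stands only at a limit, >= 131 ug/mL. The three values gather at two limits: the limit of >= 131 ug/mL in this assay, at which 2 of the 3 values shown sit, and (the limit of >= 133 ug/mL in this assay, at which 1 of the 3 values shown sits).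

Compound 4 `CNC(=O)c1cc(C(=O)NC2CC2)cn(Cc2ccccc2F)c1=O` has not yet been measured. It carries 2-fluorophenyl in place of oxan-3-yl on a saturated chain carbon bound to an aromatic nitrogen.

The closest guide is a step that the two limits leave unreadable from compound 1 to compound 3, which exchanges 3-fluorophenyl and oxan-3-yl at that same place. Also relevant is a step that the two limits leave unreadable from compound 2 to compound 3, which changes that place too. The remaining one, a step that the two limits leave unreadable from compound 1 to compound 2, concerns a group on an aromatic carbon instead. None of these steps has a readable size, so they show neither a rise nor a fall. No step beyond the usual scatter is therefore expected in this assay, in either direction. The expected change is an at least 1.0-fold lower number from compound 3 to compound 4 (0.02 log units; that floor lies within the scatter). For compound 4 the estimate is 125 ug/mL, with the result expected between 60 ug/mL and 140 ug/mL.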

Compound 4, solubility: >= 145 ug/mL
Compound 4 gave a limit, no number (the forecaster's own chance of this, stated with the estimate: 70%); at least 1.1-fold (0.06 log units) between middle value and limit.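

Compound 4, like compound 1, compound 2 and compound 3, is reported only as a limit in this assay, so none of the steps among these four compounds can be read. The compounds shown leave open whether any of these changes raises or lowers the read-out, and by how much.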